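Trading a methoxy for a fluoro on the pendant aryl ring

The source may report more compounds than this note shows. Statements on the series, on what has been measured and on what is new or still open speak of the compounds shown alone.

Among the measured compounds shown here, compound 1 `COc1ccc(-c2ncnn2-c2cc(OC)c(OC)c(OC)c2)cc1` is the one compound here with a numerical result: in a functional assay on K562 cells (Homo sapiens) for antiproliferative activity, read by MTT assay, with a stated time of 72 h (on this read-out higher numbers stand for weaker inhibition and lower numbers for stronger inhibition), compound 1 gives 950 nM. Its companion, compound 2 `COc1cc(-c2ncnn2-c2ccc([N+](=O)[O-])cc2)cc(OC)c1OC`, carries a nitro group in place of that methoxy and returns only a limit of the assay, > 10000 nM, so no number can be set against it. For the measured compounds named here, the one comparison the pair allows is that (the limit of > 10000 nM in this assay, at which 1 of the 2 values shown sits), and that tells nothing about the size of a step.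

Compound 3 `COc1cc(-n2ncnc2-c2ccc(F)cc2)cc(OC)c1OC` has not yet been measured. It differs from compound 1 in one place: fluoro in place of methoxy on an aromatic carbon, that is, 4-methoxyphenyl to 4-fluorophenyl, on an aromatic carbon of a six-membered aromatic ring of carbon only. Going by the values given here, no measured step of this kind is available, so the expected size of the move rests on compound 1 alone. A loss of some potency, beyond the usual scatter but well short of a limit, is expected, as a 3.2-fold higher number from compound 1 to compound 3 (0.50 log units; beyond the scatter). Compound 3 is therefore expected to give about 3000 nM in this assay, most plausibly between 800 nM and 12000 nM.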

Compound 3, half-maximal inhibitory concentration: > 10000 nM
Compound 3 gave a limit, no number (the forecaster's own chance of this, stated with the estimate: 20%); middle value at least 3.3-fold (0.52 log units) from the limit.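

The para methoxy of compound 1 proves to be far less forgiving than a single atom swap might suggest: moving from 4-methoxyphenyl to 4-fluorophenyl gives an at least 10-fold higher number from compound 1 to compound 3 (1.02 log units; beyond the scatter), a large step that carries the compound out of the measurable range. In this assay, going by these compounds, compound 3 gives > 10000 nM, which is a limit of the assay and not a number, so the step marks only the smallest loss that the data allow, and its true size stays unknown. This single change is thus enough to reach the limit of the assay, and that limit now holds most of the series, leaving only compound 1 with a numerical result: the limit of > 10000 nM in this assay, at which 2 of the 3 values shown sit.

The compounds shown leave open whether the methoxy itself is needed at this place or whether fluoro is simply a poor replacement for it, since a single replacement cannot separate the two. An ethoxy, a methyl, a hydroxy, a chlorine or an amine on the same aromatic carbon would show how narrow the demand at this position is, and whether any potency can be kept or gained there.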